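This account rests on a few compounds, and the source may have more. Where it says the series, first, only, none or still open, it means among the compounds named here.

Compound 2 `COc1ccc(-n2nncc2CN2C(=O)C3(C(C#N)=C(N)Oc4c(N)cc5nc6ccccc6nc5c43)c3ccccc32)cc1` stands only at a limit in a functional assay on HCT-116 cells (Homo sapiens) for antiproliferative activity, read by MTT assay, with a stated time of 48 h (on this read-out lower numbers stand for stronger inhibition and higher numbers for weaker inhibition), giving > 50000 nM, which is a limit of the assay and not a number. Compound 1 `CCOc1ccc(-n2nncc2CN2C(=O)C3(C(C#N)=C(N)Oc4c3c3nc5ccccc5nc3c3ccccc43)c3ccccc32)cc1` likewise gives only the limit > 50000 nM in this assay. Within the data shown here, both values sit at the limit of > 50000 nM in this assay, at which 2 of the 2 values shown sit, so no measured step exists. Compound 3 `Cc1cc(C)c(-n2nncc2CN2C(=O)C3(C(C#N)=C(N)Oc4c(N)cc5nc6ccccc6nc5c43)c3ccccc32)c(C)c1` differs from compound 2 by 2,4,6-trimethylphenyl in place of 4-methoxyphenyl on an aromatic nitrogen. Among the measured compounds shown here, with no measured step to rest on, the expected step that the limit leaves unreadable from compound 2 to compound 3 is none beyond the scatter, and compound 3 is expected most likely to remain at the limit. Compound 3 is estimated at 60000 nM, between 20000 nM and 200000 nM.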

Compound 3, half-maximal inhibitory concentration: > 50000 nM
Compound 3 was reported as a limit; the forecaster's own chance of this, stated with the estimate: 80%; the middle value lies beyond the limit too.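

No step can be read from compound 2 to compound 3, since both stand only at a limit: the limit of > 50000 nM in this assay, at which 3 of the 3 values shown sit.

The compounds shown leave open which change, if any, to the aryl group on the aromatic nitrogen or to the shared core would give a readable value.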